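Swapping 2-fluorobenzyl for 4-methylbenzyl on the amide nitrogen

This account rests on a few compounds, and the source may have more. Where it says the series, first, only, none or still open, it means among the compounds named here.

Measured so far in a functional assay on HeLa cells (Homo sapiens) for inhibition, read by MTT assay, with a stated time of 48 h (a lower number here means a stronger inhibitor, a higher number a weaker inhibitor), as half-maximal inhibitory concentration
compound 1 `COc1ccc2c(=O)c(/C=C/C(=O)NCc3ccccc3)coc2c1` with 33400 nM
compound 2 `COc1cccc(NC(=O)/C=C/c2coc3cc(OC)ccc3c2=O)c1` with 19200 nM
compound 3 `COc1ccc2c(=O)c(/C=C/C(=O)NCc3ccccc3F)coc2c1` with > 100000 nM (a limit of the assay, not a number)

Compound 3 has no number in this assay and gives only the limit > 100000 nM as its result.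

Compound 4 `COc1ccc2c(=O)c(/C=C/C(=O)NCc3ccc(C)cc3)coc2c1` carries 4-methylphenyl in place of 2-fluorophenyl on a saturated chain carbon bound to an amide-type nitrogen and the same change reads 2-fluorobenzyl to 4-methylbenzyl.

The closest measured change is fluoro in place of hydrogen on an aromatic carbon, which gave an at least 2.9-fold higher number from compound 1 to compound 3 (0.47 log units; beyond the scatter) in this series. Among the measured compounds shown here, the move to compound 4 removes that fluoro, although no measured compound carries 4-methylphenyl. Changing the group on the amide-type nitrogen does not always shift the result, as a 1.7-fold lower number from compound 1 to compound 2 (0.24 log units; within the scatter) shows. The comparison with compound 2 gave an at least 5.2-fold higher number from compound 2 to compound 3 (0.71 log units; beyond the scatter) and points the same way.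

A step toward a lower number in this assay is therefore expected, roughly the size of the fluoro step and in reverse, so that compound 4 should fall near compound 1 with 33400 nM as its reference. Compound 4 may still return only a limit. The expected step is an at least 2.2-fold lower number from compound 3 to compound 4 (0.34 log units; beyond the scatter) as estimated here. The estimate for compound 4 is 45000 nM with an expected range from 15000 nM to 100000 nM in this assay.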

Compound 4, half-maximal inhibitory concentration: > 100000 nM
Compound 4 was reported as a limit; the forecaster's own chance of this, stated with the estimate: 25%; middle value at least 2.2-fold (0.34 log units) from the limit.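

In this assay, substitution on the benzyl ring of compound 1 now has two examples: methyl in place of hydrogen gives an at least 2.9-fold higher number from compound 1 to compound 4 (0.47 log units; beyond the scatter), in the same direction as the fluoro step, an at least 2.9-fold higher number from compound 1 to compound 3 (0.47 log units; beyond the scatter), so the rise seen with fluoro is not tied to that atom alone. Set against the 3-methoxyphenyl group on the amide nitrogen, 4-methylbenzyl gives an at least 5.2-fold higher number from compound 2 to compound 4 (0.71 log units; beyond the scatter), so compound 2 and compound 1 both carry lower numbers than the substituted benzyl compounds. Compound 3 and compound 4 both stand at a limit, so the step between them cannot be read and no order between 2-fluorobenzyl and 4-methylbenzyl follows: the limit of > 100000 nM in this assay, at which 2 of the 4 values shown sit.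

Open, as far as these compounds go, is whether any group on the benzyl ring, such as an amine or a carboxylic acid, would return a number in this assay rather than a limit. From the compounds shown here alone, the full size of the steps from compound 1 to the two substituted benzyl compounds also stays open, each being only a lower bound.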